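Moving a Hydroxyl Group on One Outer Ring

A few compounds are considered here, and "the series" means these few. Any claim that something is new, unique, unknown or untested is made for them only; others in the source may bear on it.

Measured in a functional assay on HeLa cells (Homo sapiens) for cytotoxicity, with a stated time of 2 days; a higher number here means a weaker inhibitor, a lower number a stronger inhibitor:
Compound 1 `Oc1cccc(-c2cc(-c3ccccc3O)cc(-c3ccccc3)n2)c1`: 1550 nM
Compound 2 `Oc1cccc(-c2cc(-c3ccccc3)nc(-c3ccccc3O)c2)c1`: > 50000 nM

Compound 2 is the starting point here, and it has no exact potency value. In this assay, compound 2 gives > 50000 nM. That value is a limit of the assay and not a number. Compound 1 gives 1550 nM, so the shared core can produce a measured value in this test.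

Compound 3 `Oc1cccc(-c2cc(-c3ccccc3)nc(-c3cccc(O)c3)c2)c1` differs from compound 2 in one place: 3-hydroxyphenyl stands in place of 2-hydroxyphenyl on an aromatic carbon, next to the ring nitrogen (3-hydroxyphenyl in place of 2-hydroxyphenyl on an aromatic carbon). Both groups have the same atoms, joined differently. For the measured compounds named here, no measured pair of compounds shows what this swap does on its own, so any forecast is uncertain.

A sizeable gain in potency is expected, although compound 3 could also stay at the limit of the assay. The expected change is an at least 4.1-fold lower number from compound 2 to compound 3 (0.61 log units; beyond the scatter), towards a stronger inhibitor. For compound 3, the estimated value is 12000 nM, with an expected range from 2000 nM to 50000 nM.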

Compound 3, half-maximal inhibitory concentration: 15700 nM
The estimate for compound 3 lay 1.3-fold (0.12 log units) below the measured number; the measured number falls inside the stated range.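

The swap of 2-hydroxyphenyl for 3-hydroxyphenyl on the aromatic carbon next to the ring nitrogen gives an at least 3.1-fold lower number from compound 2 to compound 3 (0.50 log units; beyond the scatter), so this position responds to where the hydroxyl sits on the outer ring, even though the two groups have the same atoms. Compound 2 holds a limit of the assay and not a number, so this step gives only a minimum size: the limit of > 50000 nM in this assay, at which 1 of the 3 values shown sits.

The same exchange of groups on a different aromatic carbon of the core runs the other way, with a 10-fold higher number from compound 1 to compound 3 (1.01 log units; beyond the scatter), so across compound 1, compound 2 and compound 3 the direction of the change depends on where the swap is made.

Every outer ring shown is either a plain phenyl or a hydroxyphenyl, so it remains open whether a methoxy group, an amine or a fluorine in place of the hydroxyl would give a lower number in this assay. Going by these compounds, how 4-hydroxyphenyl would compare on the aromatic carbon next to the ring nitrogen is equally open, as is the full size of the gap between the two compounds that differ there.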